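Swapping the aryl group on a saturated chain carbon

This account rests on a few compounds, and the source may have more. Where it says the series, first, only, none or still open, it means among the compounds named here.

Measured compounds:
- compound 1 `N#Cc1ccccc1C1OCC(C/C=C\CCC(=O)O)C(c2cccnc2)O1`: 245 nM
- compound 2 `O=C(O)CC/C=C\CC1COC(c2ccc(Cl)cc2Cl)OC1c1cccnc1`: 891 nM
- compound 3 `Cc1ccc(OC(C)(C)C2OCC(C/C=C\CCC(=O)O)C(c3cccnc3)O2)cc1`: 631 nM

In a functional assay for inhibition, with Homo sapiens as the target (on this read-out higher numbers stand for weaker binding and lower numbers for tighter binding), compound 3 stands second highest of the three numbers, close to compound 2 and clearly above compound 1. Compound 4 `CC(C)(Cc1ccc(F)cc1C#N)C1OCC(C/C=C\CCC(=O)O)C(c2cccnc2)O1` differs from compound 3 as follows: a group of 10 heavy atoms (8 carbon, 1 nitrogen, 1 fluorine; one six-membered aromatic ring of carbon only) in place of a group of 8 heavy atoms (7 carbon, 1 oxygen; one six-membered aromatic ring of carbon only), on a saturated chain carbon bound to two saturated chain carbons and a saturated ring carbon. Going by the values given here, the only measured step, a 3.6-fold higher number from compound 1 to compound 2 (0.56 log units; beyond the scatter), changes a group on a saturated ring carbon, not on the chain carbon altered here, so it bears only loosely on this change; it does show that such swaps move this read-out modestly. A modest step toward tighter binding is therefore expected, a 1.6-fold lower number from compound 3 to compound 4 (0.20 log units; within the scatter), with wide uncertainty. Compound 4 is estimated at 400 nM, likely between 130 nM and 1300 nM.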

Compound 4, dissociation constant: 2.19 nM
Beside the measured number, compound 4's estimate is 180-fold (2.26 log units) above it, and the stated range ends above it.
By their numbers in this assay, from the lowest: compound 4; then compound 1; then compounds 3 and 2 (each within the scatter of the next).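

At this saturated chain carbon, the swap gives a 290-fold lower number from compound 3 to compound 4 (2.46 log units; beyond the scatter) in this assay, and this large step dwarfs the only earlier one, a 3.6-fold higher number from compound 1 to compound 2 (0.56 log units; beyond the scatter), which sat on a saturated ring carbon. Going by these compounds alone, the group at this chain carbon can therefore move the read-out far more than the earlier compounds suggested. Nothing measured here explains the size of this step. The compounds shown leave open whether the fluorine, the nitrile or the loss of the oxygen accounts for it. From the compounds shown here alone, whether an unsubstituted phenyl ring or an amine in the same group would keep this gain also remains open.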